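Inverting the stereocentre of compound 3

The source may report more compounds than this note shows. Statements on the series, on what has been measured and on what is new or still open speak of the compounds shown alone.

Measured so far in a functional assay with Rattus norvegicus as the target; on this read-out higher numbers stand for weaker inhibition and lower numbers for stronger inhibition:
- compound 1 `CC1(C)C[C@@H](c2cccc[n+]2[O-])c2cc(C#N)ccc2O1` gives 75 nM
- compound 2 `CC1(C)C[C@H](c2cccc[n+]2[O-])c2cc(C#N)ccc2O1` gives 210 nM
- compound 3 `CC1(C)C[C@@H](N2CCCC2=O)c2cc(C#N)ccc2O1` gives 520 nM

Compound 3 has the highest of the three numbers, beyond the scatter from both others, and a 6.9-fold higher number from compound 1 to compound 3 (0.84 log units; beyond the scatter) marks its distance from the lowest. Compound 4 `CC1(C)C[C@H](N2CCCC2=O)c2cc(C#N)ccc2O1` departs from compound 3 in one way: the two compounds have the same atoms and bonds and differ only in configuration as drawn: 1 of 1 stereo elements differ; a stereocentre at a saturated ring carbon is drawn R in compound 3 and S in compound 4 and nothing else. Going by the values given here, the one measured step of this kind is a 2.8-fold higher number from compound 1 to compound 2 (0.45 log units; beyond the scatter) and it runs from R to S, resting on configuration alone given the fact that compounds 1 and 2 differ only in the configuration as drawn here. A single pair with a different group on that carbon is thin ground, but a modest rise in the number is expected in this assay again. The expected size is a 2.9-fold higher number from compound 3 to compound 4 (0.46 log units; beyond the scatter) on this reasoning. Compound 4 is estimated at 1500 nM with an expected range of 600 nM to 4500 nM overall.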

Compound 4, half-maximal inhibitory concentration: 1150 nM
Compound 4: the middle estimate sits 1.3-fold (0.12 log units) above what was measured, within the range that was stated.
By their numbers in this assay, from the lowest: compound 1; then compound 2; then compound 3; then compound 4.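

With the five-membered non-aromatic group on the saturated ring carbon, the S form again gives the higher number in this assay, with a 2.2-fold higher number from compound 3 to compound 4 (0.34 log units; beyond the scatter), the same direction as the pair of compounds 1 and 2. This step rests on configuration alone: the fact that compounds 3 and 4 differ only in the configuration as drawn
The exchange of groups also carries over to the S configuration, with a 5.5-fold higher number from compound 2 to compound 4 (0.74 log units; beyond the scatter), close to its size in the R configuration: the same change on two cores in this assay, a 6.9-fold higher number (0.84 log units; beyond the scatter) from compound 1 to compound 3 and a 5.5-fold higher number (0.74 log units; beyond the scatter) from compound 2 to compound 4, 1.3-fold (0.10 log units) apart, within the scatter of two such steps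

As far as these compounds go, whether an open-chain amide or an amine on that carbon keeps the same order of R and S remains open. Also open, from the compounds shown here alone, is how the series responds when a carboxylic acid replaces the nitrile on the shared core.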